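This account rests on a few compounds, and the source may have more. Where it says the series, first, only, none or still open, it means among the compounds named here.

Measured compounds:
compound 1 `COc1cc(N2CCNCC2)cnc1Br` with 180 nM in an assay (strain Wistar) for binding affinity to Neuronal acetylcholine receptor; alpha4/beta2 (Rattus norvegicus); on this read-out higher numbers stand for weaker inhibition and lower numbers for stronger inhibition
compound 2 `C/C=C\Oc1cncc(N2CCC3CCC(C2)N3)c1` with 1.9 nM in this assay

Within the data shown here, of the two numbers known so far, compound 2 has the lower one; compound 1 sits well above it, a gap that lies beyond the usual scatter of this assay. Compound 3 `CCOc1cncc(N2CCC3CCC(C2)N3)c1` has not yet been measured. Compared with compound 2, it carries ethyl in place of prop-1-en-1-yl on an oxygen on an aromatic ring. Among the measured compounds shown here, no two measured compounds differ in this one place, so nothing known here tells how such a swap shifts the read-out. The two groups are both short carbon chains of nearly the same size on the same oxygen, so the account expects the step from compound 2 to compound 3 in this assay, a 1.6-fold higher number from compound 2 to compound 3 (0.20 log units; within the scatter), to be small and not beyond the scatter, with a slight lean toward a higher number. For compound 3 the estimated result is 3 nM, with a range from 1 nM to 10 nM.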

Compound 3, half-maximal inhibitory concentration: 6.5 nM
Compound 3: the middle estimate sits 2.2-fold (0.34 log units) below what was measured, within the range that was stated.
By their numbers in this assay, from the lowest: compound 2; then compound 3; then compound 1.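

Among these compounds, putting ethyl in place of prop-1-en-1-yl on this oxygen gives, in this assay, a 3.4-fold higher number from compound 2 to compound 3 (0.53 log units; beyond the scatter) as the first step in this set that can be read at a single place. Small as the change is, with one carbon and the double bond outside aromatic rings leaving together, it moves the read-out modestly past the scatter, so this position does not treat two short carbon chains as equivalent. Nothing on hand gives a reason for this step.

The compounds shown do not tell whether the lost carbon or the lost double bond accounts for the step, a question that a saturated propyl chain on the same oxygen would address. They also leave open how a longer chain such as butyl, or a chain ending in an amine, would read here.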